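A few compounds are considered here, and "the series" means these few. Any claim that something is new, unique, unknown or untested is made for them only; others in the source may bear on it.

In a functional assay on MDA-MB-231 cells (Homo sapiens) for cytotoxicity, read by MTT assay, with a stated time of 48 h (on this read-out lower numbers stand for stronger inhibition and higher numbers for weaker inhibition), the account begins with compound 1 `Cc1ccc(Cn2cc(COc3ccc4c(=O)ccoc4c3)nn2)cc1`, compound 2 `O=c1ccoc2cc(OCc3cn(Cc4ccccc4Br)nn3)ccc12` and compound 3 `O=c1ccoc2cc(OCc3cn(Cc4ccccc4)nn3)ccc12`, three compounds that share one core and differ only in the group on a saturated chain carbon bound to an aromatic nitrogen. Compound 1 gives > 100000 nM, which is a limit of the assay and not a number. Compound 2 likewise returns only a limit, > 100000 nM. Compound 3 too stops at a limit, > 100000 nM. All three values rest at the limit of > 100000 nM in this assay, at which 3 of the 3 values shown sit, so compound 2 stands level with both of its neighbours and no order among them can be read. The step that the two limits leave unreadable from compound 1 to compound 2, the step that the two limits leave unreadable from compound 1 to compound 3 and the step that the two limits leave unreadable from compound 2 to compound 3 are each unreadable, both of their ends being limits. Compound 4 `O=c1ccoc2cc(OCc3cn(Cc4ccc(Br)cc4)nn3)ccc12` has not yet been measured in this assay; it differs from compound 2 by 4-bromophenyl in place of 2-bromophenyl on a saturated chain carbon bound to an aromatic nitrogen. Every measured step that bears on this change shows no size at all, so no direction and no magnitude can be drawn from them. The expected step from compound 2 to compound 4 is therefore a number no higher from compound 2 to compound 4 (the limit leaves the size open), nothing beyond the scatter. Compound 4 is estimated to give 100000 nM, in a range from 30000 nM to 300000 nM, and most probably again as a limit rather than a number.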

Compound 4, half-maximal inhibitory concentration: > 100000 nM
Compound 4: no number, only a limit; the forecaster's own chance of this, stated with the estimate: 85%; the middle value lies on the limit itself.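

In this assay compound 4 gives > 100000 nM, which is a limit of the assay and not a number. Its steps with compound 1, compound 2 and compound 3 therefore cannot be read, as every value is a limit: the limit of > 100000 nM in this assay, at which 4 of the 4 values shown sit. The compounds shown leave open whether any change to this group alters the cytotoxicity at all.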